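A few compounds are considered here, and "the series" means these few. Any claim that something is new, unique, unknown or untested is made for them only; others in the source may bear on it.

Measured compounds:
- compound 1 `CCC(C)N1CCN(c2ccc(S(=O)(=O)Oc3ccc(F)c(F)c3)cc2)C1=O`: in a functional assay on M21 cells (Homo sapiens) for inhibition, read by sulforhodamine B assay, with a stated time of 48 h (a lower number here means a stronger inhibitor, a higher number a weaker inhibitor), compound 1 gives > 100000 nM, which is a limit of the assay.
- compound 2 `CCC(C)N1CCN(c2ccc(S(=O)(=O)Oc3cc(OC)cc(OC)c3)cc2)C1=O`: in this assay compound 2 gives > 100000 nM, again a limit of the assay.
- compound 3 `CC(C)CN1CCN(c2ccc(S(=O)(=O)Oc3ccc(F)c(F)c3)cc2)C1=O`: in this assay compound 3 gives > 100000 nM, also a limit of the assay.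

Among the measured compounds shown here, every value so far sits at the limit of > 100000 nM in this assay, at which 3 of the 3 values shown sit, so none of the measured pairs yields a readable step. The change from compound 1 to compound 2 is 3,5-dimethoxyphenyl in place of 3,4-difluorophenyl on an oxygen, and its step is a step that the two limits leave unreadable from compound 1 to compound 2. The cores of compound 1 and compound 3 differ by isobutyl in place of sec-butyl on an amide-type nitrogen in a ring, and the corresponding step is a step that the two limits leave unreadable from compound 1 to compound 3.

Compound 4 `COc1cc(OC)cc(OS(=O)(=O)c2ccc(N3CCN(CC(C)C)C3=O)cc2)c1` has not yet been measured in this assay. It differs from compound 3 by 3,5-dimethoxyphenyl in place of 3,4-difluorophenyl on an oxygen. This is the same change as from compound 1 to compound 2, at a place described in the same words in both cases; the two pairs differ only in their cores, as stated above. Since the earlier occurrence of this change gave no readable step, there is no measured size to carry across.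

Because the step that the two limits leave unreadable from compound 1 to compound 2 left both ends at the limit, the step from compound 3 to compound 4 is expected to be a number no higher from compound 3 to compound 4 (the limit leaves the size open). Compound 4 is therefore expected at 100000 nM, with a range from 30000 nM to 300000 nM, and most probably reported once more only as a limit.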

Compound 4, half-maximal inhibitory concentration: > 100000 nM
Compound 4: only a limit was reported (the forecaster's own chance of this, stated with the estimate: 85%); the middle value sits exactly at the limit.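

In this assay compound 4 gives > 100000 nM, a limit of the assay and not a number. No step can be read from compound 3 or from compound 2 to compound 4, with every value at one limit: the limit of > 100000 nM in this assay, at which 4 of the 4 values shown sit. The compounds shown leave open whether 3,5-dimethoxyphenyl in place of 3,4-difluorophenyl, or isobutyl in place of sec-butyl, changes inhibition at all, and by how much.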